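Chloro for bromo on a shared core

The source may report more compounds than this note shows. Statements on the series, on what has been measured and on what is new or still open speak of the compounds shown alone.

Compound 1 `CCN(CC)CN1C(=O)/C(=N\c2nc3ccc(C)cc3s2)c2ccccc21` gives 74800 nM in a functional assay on MCF7 cells (Homo sapiens) for cytotoxicity, read by sulforhodamine B assay, with a stated time of 48 h; on this read-out higher numbers stand for weaker inhibition of growth and lower numbers for stronger inhibition of growth. Compound 2 `CCN(CC)CN1C(=O)/C(=N\c2nc3ccc(C)cc3s2)c2c(Br)cccc21` gives 30200 nM, and compound 3 `Cc1ccc2nc(/N=C3\C(=O)N(CN(C)C)c4cccc(Br)c43)sc2c1` gives 18000 nM. Compound 2 thus holds the second highest of the three numbers: the step of a 1.7-fold lower number from compound 2 to compound 3 (0.22 log units; within the scatter) stays within the scatter, while the step of a 2.5-fold lower number from compound 1 to compound 2 (0.39 log units; beyond the scatter) lies beyond it. Compound 4 `CCN(CC)CN1C(=O)/C(=N\c2nc3ccc(C)cc3s2)c2c(Cl)cccc21` differs from compound 2 by chloro in place of bromo on an aromatic carbon. Among the measured compounds shown here, only the bromo step from compound 1 to compound 2 touches this position, and it was modest; no measured step exchanges one halogen for another. Compound 4 is therefore expected to stay close to compound 2, with a step of a 1.2-fold higher number from compound 2 to compound 4 (0.08 log units; within the scatter) not beyond the scatter, and its estimate is 36000 nM within 16000 nM to 80000 nM.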

Compound 4, concentration for 50% growth inhibition: 19200 nM
Estimate against measurement, compound 4: 1.9-fold (0.27 log units) above; the range from low to high includes it.
By their numbers in this assay, from the lowest: compounds 3, 4 and 2 (each within the scatter of the next); then compound 1.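

In this assay the exchange of one halogen for the other gives a 1.6-fold lower number from compound 2 to compound 4 (0.20 log units; within the scatter) and so leaves bromo and chloro at this position indistinguishable. Chloro in place of hydrogen gives a 3.9-fold lower number from compound 1 to compound 4 (0.59 log units; beyond the scatter) and so shows that the lower number on this aromatic carbon is not tied to bromo alone. Nothing measured alongside these numbers bears on why a halogen here lowers them.

As far as these compounds go, whether fluoro, iodo, methoxy or a nitrile at this place would give a similar number stays open. So does whether chloro behaves like bromo when dimethylamino replaces diethylamino on the chain.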